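The compounds below may be only part of what the source reports. "The series", "measured", "known", "first", "only" and "open" are said of these compounds alone.

Measured in an ADME assay on microsomes from liver (Homo sapiens) for metabolic stability, read by LC-MS, with NADPH named in the record, with a stated time of 60 min, tested at 1 uM, in the absence of a further agent; a higher number here means that more of the compound is left, a lower number that less of the compound is left:
- Compound 1 (`CC(=O)N[C@@H]1CCN(c2cc(C)nn3c(-c4ccc(C#N)cc4)c(C)nc23)C1`) gives > 95%, a limit.
- Compound 2 (`COc1cc(-c2c(C)nc3c(N4CC[C@@H](NC(C)=O)C4)cc(C)nn23)ccc1F`) gives > 95%, a limit.
- Compound 3 (`CC(=O)N[C@@H]1CCN(c2cc(C)nn3c(-c4cccc(S(=O)(=O)N(C)C)c4)c(C)nc23)C1`) gives > 95%, a limit.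

Compound 2 therefore has no number to start from, only the limit > 95%. It shares this position with the rest of the series, which stands at the limit of > 95% in this assay, at which 3 of the 3 values shown sit.

Compound 4 (`CC(=O)N[C@@H]1CCN(c2cc(C)nn3c(-c4cccs4)c(C)nc23)C1`) has not yet been measured. It differs from compound 2 in one place: thiophen-2-yl in place of 4-fluoro-3-methoxyphenyl on an aromatic carbon. The thiophen-2-yl sits on an aromatic carbon of a five-membered aromatic ring with 2 nitrogen, part of a fused or bridged system of two rings.

Among the compounds with values here, the one measured step at this place is a step that the two limits leave unreadable from compound 1 to compound 2, so it offers no size to carry over. Nor has any compound measured so far a thiophen-2-yl group. The expectation rests only on the series staying at one limit, and it is a loose one because the limit of > 95% in this assay, at which 3 of the 3 values shown sit, gives no number for any compound.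

Expected here is a number at least 2 percentage points lower from compound 2 to compound 4 (that floor lies within the scatter), which means no step beyond the scatter, and any drift is expected towards less compound left.

For compound 4 the estimate is 93%, with an expected range of 75% to 100%.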

Compound 4, percent of the compound remaining: > 95%
Compound 4: only a limit was reported; the forecaster's own chance of this, stated with the estimate: 60%; at least 2 percentage points between middle value and limit.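

The steps from compound 1 and from compound 2 to compound 4 cannot be read, as in this assay the series rests on a single limit: the limit of > 95% in this assay, at which 4 of the 4 values shown sit.

The compounds shown leave open whether any group at this place on the shared core would give a readable number, and how far thiophen-2-yl, 4-cyanophenyl and 4-fluoro-3-methoxyphenyl differ.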